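From pyridin-3-yl to 4-carboxyphenyl on the shared core

The source may hold more compounds than are shown below. What is called first, only, known or untested is meant among the compounds shown, and "the series" means these compounds.

Going by the values given here, in an ADME assay on S9 fraction from liver (Rattus norvegicus) for metabolic stability, read by LC-MS, using NADPH, with a stated time of 30 min (on this read-out higher numbers stand for a more stable compound and lower numbers for a less stable compound), compound 2 `CCCCCCCCc1ccc(OCC(=O)Cn2nnc(-c3cccnc3)n2)cc1` gives 12%, the lower of the two numbers so far, while compound 1 `CCCCCCCCc1ccc(OCC(=O)Cn2nnc(-c3ccc(Cl)cc3)n2)cc1` gives 74%. Compound 3 `CCCCCCCCc1ccc(OCC(=O)Cn2nnc(-c3ccc(C(=O)O)cc3)n2)cc1` keeps the shared core and alters one group: 4-carboxyphenyl in place of pyridin-3-yl on an aromatic carbon. In short, 4-carboxyphenyl takes the place of pyridin-3-yl on the same aromatic carbon. Among the compounds with values here, one measured step bears on this change: a number 62 percentage points lower from compound 1 to compound 2 (beyond the scatter), a large drop that came with pyridin-3-yl replacing 4-chlorophenyl at that same place. Like compound 1, which gives 74%, compound 3 carries a six-membered aromatic ring of carbon only, but no measured compound yet carries a 4-carboxyphenyl group, so only a partial return towards that number is assumed. The expected change is a number 46 percentage points higher from compound 2 to compound 3 (beyond the scatter), a large upward step estimated to lie beyond the scatter. For compound 3 the estimate is 58%, with an expected range from 30% to 85%.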

Compound 3, percent of the compound remaining: < 5%
Compound 3 was reported as a limit; the forecaster's own chance of this, stated with the estimate: 2%; middle value at least 53 percentage points away from the limit.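

Compound 3 is reported as a limit of the assay, not as a number: the limit of < 5% in this assay, at which 1 of the 3 values shown sits.

Carboxy in place of chloro on the six-membered aromatic ring of carbon only brings a number at least 69 percentage points lower from compound 1 to compound 3 (beyond the scatter), so in this assay having such a ring at this place does not by itself keep the number high, and the group on that ring matters as well. Against the pyridin-3-yl group the result is less sharp, with a number at least 7 percentage points lower from compound 2 to compound 3 (that floor lies within the scatter), so these two compounds cannot be firmly separated.

From the compounds shown here alone, it remains open whether this loss belongs to the carboxylic acid itself or would follow other groups in place of chloro. A methyl ester or a primary amide in place of the carboxy would help to tell these apart.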